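This account rests on a few compounds, and the source may have more. Where it says the series, first, only, none or still open, it means among the compounds named here.

In a functional assay on DU-145 cells (Homo sapiens) for antiproliferative activity, read by MTT assay, with a stated time of 48 h (a lower number here means a stronger inhibitor, a higher number a weaker inhibitor), compound 1 `C/C(=C\CC/C(C)=C/CC[C@@H]1[C@@]2(C)CCC(=O)C(C)(C)[C@H]2CC[C@@]1(C)O)CC/C=C(\C)C(=O)OCc1cn(-c2ccc([N+](=O)[O-])cc2)nn1` gives > 150000 nM, which is a limit of the assay. Compound 2 `COc1cccc(-n2cc(COC(=O)/C(C)=C/CC/C(C)=C/CC/C(C)=C/CC[C@@H]3[C@@]4(C)CCC(=O)C(C)(C)[C@H]4CC[C@@]3(C)O)nn2)c1` gives > 150000 nM, also a limit. Compound 3 `C/C(=C\CC/C(C)=C/CC[C@@H]1[C@@]2(C)CCC(=O)C(C)(C)[C@H]2CC[C@@]1(C)O)CC/C=C(\C)C(=O)OCc1cn(-c2ccccc2F)nn1` gives > 150000 nM, again a limit and not a number. Within the data shown here, the series so far stands at the limit of > 150000 nM in this assay, at which 3 of the 3 values shown sit. Compound 4 `C/C(=C\CC/C(C)=C/CC[C@@H]1[C@@]2(C)CCC(=O)C(C)(C)[C@H]2CC[C@@]1(C)O)CC/C=C(\C)C(=O)OCc1cn(-c2cccc(O)c2)nn1` carries 3-hydroxyphenyl in place of 2-fluorophenyl on an aromatic nitrogen. The measured steps that bear on this exchange at the same place are a step that the two limits leave unreadable from compound 1 to compound 2, a step that the two limits leave unreadable from compound 1 to compound 3 and a step that the two limits leave unreadable from compound 2 to compound 3. None has a readable size. No step beyond the scatter is therefore expected in this assay, and no direction can be given. For compound 4 the estimated value is 150000 nM, with an expected range of 70000 nM to 250000 nM. This corresponds to an expected a number no higher from compound 3 to compound 4 (the limit leaves the size open).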

Compound 4, half-maximal inhibitory concentration: 28400 nM
The estimate for compound 4 lay 5.3-fold (0.72 log units) above the measured number; measured number outside the range, below it.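

The aryl group on the aromatic nitrogen can bring the read-out in this assay off the limit, which the earlier compounds did not show: the limit of > 150000 nM in this assay, at which 3 of the 4 values shown sit.

3-Hydroxyphenyl gives an at least 5.2-fold lower number from compound 3 to compound 4 (0.72 log units; beyond the scatter), and in place of 4-nitrophenyl it gives an at least 5.2-fold lower number from compound 1 to compound 4 (0.72 log units; beyond the scatter). Hydrogen in place of methyl on the oxygen is enough on its own, with an at least 5.2-fold lower number from compound 2 to compound 4 (0.72 log units; beyond the scatter).

The steps among compound 1, compound 2 and compound 3 cannot be read, and the steps to compound 4 have only a lower bound on their size. From the compounds shown here alone, whether an amine or a carboxylic acid in place of the hydroxyl does the same stays open.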